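Swapping Hydroxy for Chloro: What to Expect

The compounds below may be only part of what the source reports. "The series", "measured", "known", "first", "only" and "open" are said of these compounds alone.

Compound 2 (`CC1=CC[C@H](C(C)(C)NC(=S)N/N=C/c2ccccc2O)CC1`) gives 10900 nM in a functional assay on HT-29 cells (Homo sapiens) for inhibition, read by sulforhodamine B assay, with a stated time of 48 h (on this read-out lower numbers stand for stronger inhibition of growth and higher numbers for weaker inhibition of growth), the higher of the two numbers measured, although compound 1 (`COc1ccc(/C=N/NC(=S)NC(C)(C)[C@H]2CC=C(C)CC2)cc1`), with 8400 nM, sits so close that the two cannot be told apart. Compound 3 (`CC1=CC[C@H](C(C)(C)NC(=S)N/N=C/c2ccccc2Cl)CC1`) differs from compound 2 by chloro in place of hydroxy on an aromatic carbon. Among the measured compounds shown here, the only measured step, a 1.3-fold higher number from compound 1 to compound 2 (0.11 log units; within the scatter), also altered the group on that ring and stayed within the scatter; no measured step exchanges hydroxy for chloro. Compound 3 is therefore expected to shift little, a 1.1-fold lower number from compound 2 to compound 3 (0.06 log units; within the scatter). Compound 3 is estimated at 9500 nM, with a range from 3500 nM to 26000 nM.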

Compound 3, concentration for 50% growth inhibition: 71300 nM
Compound 3: middle estimate off by 7.5-fold (0.88 log units), on the low side; the measured number lies above the stated range.
By their numbers in this assay, from the lowest: compounds 1 and 2 (each within the scatter of the next); then compound 3.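

Unlike the earlier change on this ring, chloro in place of hydroxy on this aromatic carbon gives a 6.5-fold higher number from compound 2 to compound 3 (0.82 log units; beyond the scatter) in this assay, so the group here can clearly affect inhibition of growth. Changing 4-methoxyphenyl to 2-chlorophenyl likewise gives an 8.5-fold higher number from compound 1 to compound 3 (0.93 log units; beyond the scatter), leaving compound 3 the weakest of the three. No available evidence accounts for this drop.

From the compounds shown here alone, whether an amine or a methyl group on the same aromatic carbon would read closer to hydroxy or to chloro remains open. So does whether chloro has the same effect elsewhere on the ring.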